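Sulfonyl aryl exchange on the shared core: pyridyl to methylpyrazolyl

A few compounds are considered here, and "the series" means these few. Any claim that something is new, unique, unknown or untested is made for them only; others in the source may bear on it.

For the measured compounds named here, compound 2 `O=c1c2[nH]c(Cc3ccc(NS(=O)(=O)c4cccnc4)cc3)nc2n(CC2CC2)c(=O)n1Cc1ccccc1F` gives 5500 nM in an assay on H4IIE cells for inhibition of phosphoenolpyruvate carboxykinase, cytosolic [GTP] (Rattus norvegicus) (a lower number here means that less compound is needed, a higher number that more compound is needed for the effect), and holds the lowest of the two numbers known. Its nearest neighbour is compound 1 `Cc1nc(N)sc1S(=O)(=O)Nc1ccc(Cc2nc3c([nH]2)c(=O)n(Cc2ccccc2F)c(=O)n3CC2CC2)cc1` with 8200 nM in this assay; the step of a 1.5-fold lower number from compound 1 to compound 2 (0.17 log units; within the scatter) is within the scatter, so the two stand level. Compound 3 `Cn1cc(S(=O)(=O)Nc2ccc(Cc3nc4c([nH]3)c(=O)n(Cc3ccccc3F)c(=O)n4CC3CC3)cc2)cn1` is not yet measured; it differs from compound 2 in one place: 1-methyl-1H-pyrazol-4-yl in place of pyridin-3-yl on a sulfonyl sulfur. Going by the values given here, the only measured step that bears on this site is a 1.5-fold lower number from compound 1 to compound 2 (0.17 log units; within the scatter), where a different replacement on the same sulfonyl sulfur left the number essentially unmoved. On that basis no step beyond the scatter is expected in this assay in either direction, and the estimate for compound 3 means no change at the digits printed from compound 2 to compound 3 (within the scatter). Compound 3 is therefore expected to give about 5500 nM in this assay, with a range from 2500 nM to 12000 nM.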

Compound 3, half-maximal effective concentration: 8750 nM
Compound 3: middle estimate off by 1.6-fold (0.20 log units), on the low side, and the stated range covers the measured number.
By their numbers in this assay, from the lowest: compounds 2, 1 and 3 (each within the scatter of the next).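

In this assay, for the compounds shown here, the sulfonyl sulfur has now carried three different aromatic rings on an unchanged shared core, and no step between them leaves the scatter. Going by these compounds alone, the five-membered 1-methyl-1H-pyrazol-4-yl ring with 2 hetero atoms, in place of the six-membered pyridin-3-yl ring with 1 hetero atom, gives no step that can be told from the scatter (a 1.6-fold higher number from compound 2 to compound 3 (0.20 log units; within the scatter)), and the same holds against 2-amino-4-methyl-1,3-thiazol-5-yl (a 1.1-fold higher number from compound 1 to compound 3 (0.03 log units; within the scatter)). Nothing available explains this flat response.

As far as these compounds go, whether a non-aromatic group on the sulfonyl sulfur, such as methyl or piperidin-1-yl, or a carboxylic acid on the aromatic ring, would move the number beyond the scatter remains open. Also open, from the compounds shown here alone, is whether the same tolerance would hold with a different core.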